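Hydroxy to methoxy on compound 1

This account rests on a few compounds, and the source may have more. Where it says the series, first, only, none or still open, it means among the compounds named here.

In a functional assay on HOP-62 cells (Homo sapiens) for cytotoxicity, read by resazurin assay, with a stated time of 72 h (a higher number here means a weaker inhibitor, a lower number a stronger inhibitor), compound 1 `O=C(/C=C/c1ccc(OCCCCO[N+](=O)[O-])c(O)c1)OCCCCO[N+](=O)[O-]` gives > 50000 nM, which is a limit and not a number. Compound 1 therefore stands at the limit of > 50000 nM in this assay, at which 2 of the 3 values shown sit. Compound 2 `COc1cc(/C=C/C(=O)OCCCO[N+](=O)[O-])ccc1OCCCO[N+](=O)[O-]` gives > 50000 nM, which is also a limit. Among the compounds with values here, compound 3 `COc1cc(/C=C/C(=O)OCCCCCO[N+](=O)[O-])ccc1O` gives 12500 nM, the only true number in the set.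

Compound 4 `COc1cc(/C=C/C(=O)OCCCCO[N+](=O)[O-])ccc1OCCCCO[N+](=O)[O-]` differs from compound 1 by one change: methyl in place of hydrogen on an oxygen on an aromatic ring. This places methyl in place of hydrogen on an oxygen on an aromatic ring, hydroxy to methoxy.

Within the data shown here, no measured pair here isolates this change, and the limit on compound 1 gives no exact starting point. No shift beyond the usual scatter is expected in this assay. The closest guide is compound 2, a methoxy compound with two nitrate ester groups, which shows the limit > 50000 nM. Compound 3, a methoxy compound with one nitrate ester group, goes against that reading with 12500 nM, so a measurable value cannot be ruled out.

The expected change is a number no higher from compound 1 to compound 4 (the limit leaves the size open). For compound 4 the estimated value is 50000 nM, with an expected range of 20000 nM to 100000 nM.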

Compound 4, half-maximal inhibitory concentration: > 50000 nM
Compound 4: only a limit was reported; the forecaster's own chance of this, stated with the estimate: 75%; the middle value lies on the limit itself.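

In this assay compound 4 gives > 50000 nM, which is a limit and not a number. Compound 1 also carries only a limit, so no step can be read between compound 1 and compound 4. The compounds shown leave open what hydroxy to methoxy does on this pair, with most values resting on one limit: the limit of > 50000 nM in this assay, at which 3 of the 4 values shown sit.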